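From an Aminoanilide Limit to an Expected Hydroxamate Value

The compounds below may be only part of what the source reports. "The series", "measured", "known", "first", "only" and "open" are said of these compounds alone.

Compound 1 `Cn1cc(-c2cc(C(C)(C)O)ccc2OC2CC2)c2cc(C(=O)NCCCCCCC(=O)NO)[nH]c2c1=O`: 5.5 nM
Compound 2 `Cn1cc(-c2ccccc2Oc2ccccc2)c2cc(C(=O)NCCCCCC(=O)Nc3ccccc3N)[nH]c2c1=O`: > 500 nM
Compound 3 `Cn1cc(-c2ccccc2Oc2ccccc2)c2cc(C(=O)NCc3ccc(C(=O)Nc4ccccc4N)cc3)[nH]c2c1=O`: > 500 nM

Of the compounds shown here, three built on a shared core have been tested in an assay on isolated protein for inhibition of protein deacetylase HDAC6 (Homo sapiens), read by fluorescence; on this read-out higher numbers stand for weaker inhibition and lower numbers for stronger inhibition. Compound 1 gives 5.5 nM. Compound 2 returns only a limit of this assay, > 500 nM. Compound 3 likewise returns only a limit, > 500 nM. Compound 2 thus stands at the weak edge of what has been measured, sitting at the limit of > 500 nM in this assay, at which 2 of the 3 values shown sit, together with compound 3, while compound 1 alone yields a number. Among the measured compounds shown here, no two measured compounds differ in a single place, so no measured step is available.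

Compound 4 `Cn1cc(-c2ccccc2Oc2ccccc2)c2cc(C(=O)NCCCCCC(=O)NO)[nH]c2c1=O` has not yet been measured. Its difference from compound 2 is hydroxy in place of 2-aminophenyl on an amide-type nitrogen. Compound 1, which also ends in a hydroxycarbamoyl group, gives 5.5 nM. The two compounds ending in a (2-aminophenyl)carbamoyl group, compound 2 and compound 3, each return only a limit of this assay. On this basis a large step toward stronger inhibition is expected, an at least 41-fold lower number from compound 2 to compound 4 (1.61 log units; beyond the scatter). Compound 4 is therefore estimated at 12 nM, within a range from 3 nM to 50 nM.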

Compound 4, half-maximal inhibitory concentration: 3.4 nM
The estimate for compound 4 lay 3.5-fold (0.55 log units) above the measured number, and the stated range covers the measured number.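

Replacing 2-aminophenyl with hydroxy on the amide-type nitrogen gives an at least 140-fold lower number from compound 2 to compound 4 (2.16 log units; beyond the scatter) in this assay, and this single pair isolates the change with the rest of compound 2 left as it stands. The earlier compounds shown here could not separate this group from the other differences among them, whereas here the weak reading of compound 2 is lifted by this one change alone, so the rest of that molecule does not prevent strong inhibition in this assay. The size of the step remains a bound, not a measured gap, since compound 2 gives only a limit of the assay: the limit of > 500 nM in this assay, at which 2 of the 4 values shown sit.

The compounds shown leave open how far the true step extends, and whether an unsubstituted phenyl, a 2-hydroxyphenyl or a methoxy on the same amide-type nitrogen would fall nearer to the hydroxy or to the 2-aminophenyl end. They also leave open whether hydroxy would produce a comparable change in compound 3, with its different link to the shared core, and whether a longer chain would alter the result in compound 4.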